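This account rests on a few compounds, and the source may have more. Where it says the series, first, only, none or still open, it means among the compounds named here.

Compound 2 `CC(C)(C)c1ccc(CN(Cc2cccc(CCC(=O)O)c2)S(C)(=O)=O)cc1` gives the lower of the two numbers recorded so far in a functional assay on HEK293 cells for agonist activity at prostaglandin E2 receptor EP2 subtype (Rattus norvegicus), read by cAMP accumulation (a higher number here means that more compound is needed for the effect, a lower number that less compound is needed), namely 48 nM. Compound 1 `CC(C)(C)c1ccc(CN(Cc2cccc(OCC(=O)O)c2)S(C)(=O)=O)cc1` gives 203 nM in this assay, and the change from compound 1 to compound 2 produced a 4.2-fold lower number from compound 1 to compound 2 (0.63 log units; beyond the scatter), a step that concerned the acid-bearing chain. Compound 3 `CCCCc1ccc(CN(Cc2cccc(CCC(=O)O)c2)S(C)(=O)=O)cc1` differs from compound 2 only in that (butyl in place of tert-butyl on an aromatic carbon), a change that leaves the acid-bearing chain untouched. Among the compounds with values here, no measured step bears on this change, since the single step known involves a different part of the shared core. There is therefore no basis for expecting a shift beyond the usual scatter, and compound 3 is expected to behave much like compound 2, with a 1.3-fold higher number from compound 2 to compound 3 (0.10 log units; within the scatter) anticipated. The estimate for compound 3 in this assay is 60 nM, within a range from 20 nM to 200 nM.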

Compound 3, half-maximal effective concentration: 34.4 nM
For compound 3 the middle estimate is 1.7-fold (0.24 log units) above the measured one; low and high end bracket the measured number.
By their numbers in this assay, from the lowest: compounds 3 and 2 (each within the scatter of the next); then compound 1.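

Exchanging tert-butyl for butyl on the aromatic carbon para to a large group gives a 1.4-fold lower number from compound 2 to compound 3 (0.14 log units; within the scatter) in this assay, so the two groups cannot be told apart at this position. The earlier step concerned only the acid-bearing chain, whereas this one shows that the number holds when these four carbons are joined differently at the other end of the molecule. Nothing available bears on why the two groups read alike.

Going by these compounds, whether a shorter chain such as methyl, a ring such as cyclohexyl, or a halogen such as chlorine would be tolerated at this position remains open. On these data alone, it is also open whether butyl and tert-butyl would still match with the carboxymethoxy chain of compound 1 in place of the 2-carboxyethyl chain.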